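This account rests on a few compounds, and the source may have more. Where it says the series, first, only, none or still open, it means among the compounds named here.

Three compounds share one core and differ only in the group carried on an amine nitrogen in a ring. In an assay on HEK293 cells for negative allosteric modulation of metabotropic glutamate receptor 5 (Homo sapiens), read by FLIPR, with a stated time of 1 h (a higher number here means a weaker inhibitor, a lower number a stronger inhibitor), compound 1 `CCN1CCc2nc(C#Cc3ccccc3)sc2C1` gives 1200 nM. Compound 2 `C(#Cc1nc2c(s1)CN(C1CCCCC1)CC2)c1ccccc1` carries cyclohexyl in place of ethyl on that nitrogen. In this assay compound 2 gives > 10000 nM, which is a limit of the assay and not a number. Compound 3 `O=C(C1CCCC1)N1CCc2nc(C#Cc3ccccc3)sc2C1` carries cyclopentylcarbonyl in place of ethyl. In this assay compound 3 gives > 10000 nM, again a limit rather than a number. So compound 3 stands at the limit of > 10000 nM in this assay, at which 2 of the 3 values shown sit, and the step from compound 1 is an at least 8.3-fold higher number from compound 1 to compound 3 (0.92 log units; beyond the scatter); the step that the two limits leave unreadable from compound 2 to compound 3.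

Compound 4 `O=C(N1CCC(F)CC1)N1CCc2nc(C#Cc3ccccc3)sc2C1` keeps the cyclopentylcarbonyl framework of compound 3 but alters it: 4-fluoropiperidin-1-yl in place of cyclopentyl on a carbonyl carbon. Among the compounds with values here, no measured step touches the carbonyl carbon; the only step that reaches compound 3 is the one from compound 1, and it says nothing about exchanging one ring on the carbonyl for another. With compound 3 sitting at a limit, the expected step that the limit leaves unreadable from compound 3 to compound 4 cannot be read as a clear change in either direction. Compound 4 is therefore expected to come out near 15000 nM in this assay, within the range 4000 nM to 50000 nM, most likely reported again only as a limit.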

Compound 4, half-maximal inhibitory concentration: > 10000 nM
Compound 4 was reported as a limit; the forecaster's own chance of this, stated with the estimate: 70%; the middle value does not contradict the limit.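

In this assay compound 4 gives > 10000 nM, which is a limit of the assay and not a number. Compound 3 also stands at a limit, so the change between compound 3 and compound 4 cannot be read: the limit of > 10000 nM in this assay, at which 3 of the 4 values shown sit. The compounds shown leave open whether cyclopentyl and 4-fluoropiperidin-1-yl on the carbonyl carbon differ at all.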